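Three-Carboxy Amino Acids: Bromo to Nitro at the Aromatic Ring

The compounds below may be only part of what the source reports. "The series", "measured", "known", "first", "only" and "open" are said of these compounds alone.

Among the three compounds measured in an in vitro assay on cells for inhibition of excitatory amino acid transporter 3 (Homo sapiens), tested at 100 uM (a lower number here means less inhibition, a higher number more inhibition at the concentration tested (going by the name of the read-out)), so far, compound 3 `N[C@H](C(=O)O)C(Cc1cccc(Br)c1)C(=O)O` sits at the bottom, giving 8%. Compound 2 `Cc1cccc(CC(C(=O)O)[C@H](N)C(=O)O)c1` gives 33%, and compound 1 `N[C@H](C(=O)O)C(Cc1ccc2ccccc2c1)C(=O)O`, which carries a fused bicyclic aromatic in place of the substituted phenyl, gives 68%. Among the compounds with values here, the one step between measured compounds that differ in a single place is a number 25 percentage points lower from compound 2 to compound 3 (beyond the scatter), so the aromatic substituent at that position clearly matters to the read-out.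

Compound 4 `N[C@H](C(=O)O)C(Cc1cccc([N+](=O)[O-])c1)C(=O)O` is the next candidate. Its change from compound 3 is nitro in place of bromo on an aromatic carbon. Within the data shown here, no measured step describes this particular swap; the only step that bears on it, the one from compound 2 to compound 3, shows that exchanging one substituent for another at this place can shift the read-out by a modest amount, and the direction for nitro cannot be read from the data. Given that compound 3 already lies near the floor of the scale, the step is expected to be a number 7 percentage points higher from compound 3 to compound 4 (within the scatter), and compound 4 is expected to give about 15%, with a plausible range from 0% to 40%.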

Compound 4, a percentage reported as inhibition, at one concentration (the size of the read-out at that concentration, not a potency): 29%
Beside the measured number, compound 4's estimate is 14 percentage points below it; the range from low to high includes it.
By their numbers in this assay, from the lowest: compound 3; then compounds 4 and 2 (each within the scatter of the next); then compound 1.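

In this assay, nitro in place of bromo on the aromatic carbon gives a number 21 percentage points higher from compound 3 to compound 4 (beyond the scatter), so the low reading of compound 3 is not the rule for this position: a different group at the same place restores a clearly higher number. Nitro in place of methyl gives a number 4 percentage points lower from compound 2 to compound 4 (within the scatter), which means these two groups cannot be told apart here, whereas the earlier step, a number 25 percentage points lower from compound 2 to compound 3 (beyond the scatter), separates bromo from methyl, and bromo therefore stands apart from both of the other groups in this small set. Nothing available explains why bromo differs from methyl and nitro in this read-out.

From the compounds shown here alone, whether an amine or a carboxylic acid at this same place would stay level with methyl and nitro or drop to the level of bromo remains open. Also open, going by these compounds, is whether chloro or methoxy would follow bromo, since three substituents on the shared core are too few to show what sets the read-out at this position.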